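Swapping a benzyl group on the amine: expected cytotoxicity

The compounds below may be only part of what the source reports. "The series", "measured", "known", "first", "only" and "open" are said of these compounds alone.

Measured compounds:
- compound 1 `CCc1ccc2[nH]c(=O)c(CN(Cc3ccc(F)cc3)Cc3ccc(C(C)(C)C)cc3)cc2c1`: > 33000 nM
- compound 2 `Cc1ccc2[nH]c(=O)c(CN(Cc3ccc(OC(F)(F)F)cc3)Cc3ccc(C(C)(C)C)cc3)cc2c1`: > 5000 nM

Both compounds share a core bearing an amine with two benzyl arms. In a toxicity assay on MDCK cells (Canis lupus familiaris) for cytotoxicity, read by crystal violet staining, with a stated time of 48 h (on this read-out lower numbers stand for higher toxicity in this test and higher numbers for lower toxicity in this test), compound 1 gives only a limit, > 33000 nM, which is the limit of > 33000 nM in this assay, at which 1 of the 2 values shown sits. Compound 2 likewise gives only a limit in this assay, > 5000 nM, which is the limit of > 5000 nM in this assay, at which 1 of the 2 values shown sits. So compound 2 stands among values that are all limits, with no number to compare.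

Compound 3 `COc1ccc(C(C)N(Cc2ccc(C(C)(C)C)cc2)Cc2cc3cc(C)ccc3[nH]c2=O)cc1Cl` is not yet measured. It differs from compound 2 in one place: 1-(3-chloro-4-methoxyphenyl)ethyl in place of 4-(trifluoromethoxy)benzyl on an amine nitrogen. Within the data shown here, with no measured step of this kind, the step from compound 2 to compound 3 is expected to stay within the usual scatter, most likely returning a limit again. For compound 3 in this assay an estimate of 15000 nM is expected, with a range from 4000 nM to 60000 nM, as a step that the limit leaves unreadable from compound 2 to compound 3.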

Compound 3, half-maximal cytotoxic concentration: > 10000 nM
Compound 3 was reported as a limit (the forecaster's own chance of this, stated with the estimate: 70%); the middle value lies beyond the limit too.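

In this assay, among these compounds, compound 2 and compound 3 both give only limits, so no step between them can be read. Still open, on these data alone, is whether 1-(3-chloro-4-methoxyphenyl)ethyl in place of 4-(trifluoromethoxy)benzyl on the amine nitrogen changes toxicity at all, and in which direction.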